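Amino for methyl on the side chain of compound 2

The source may hold more compounds than are shown below. What is called first, only, known or untested is meant among the compounds shown, and "the series" means these compounds.

Compound 2 `CCCC[C@H](N)C(=O)N[C@@H]1C[C@H](C(=O)NO)N(S(=O)(=O)c2ccc(OC)cc2)C1` carries a free amine where compound 1 `CCCC[C@H](NC(=O)OC(C)(C)C)C(=O)N[C@@H]1C[C@H](C(=O)NO)N(S(=O)(=O)c2ccc(OC)cc2)C1` carries a tert-butoxycarbonyl group, and the two sit within the scatter of each other: in an assay on isolated protein for inhibition of matrix metalloproteinase-9 (Homo sapiens), read by fluorescence (a higher number here means a weaker inhibitor, a lower number a stronger inhibitor), compound 1 gives 131 nM, and compound 2 gives 98 nM, a 1.3-fold lower number from compound 1 to compound 2 (0.13 log units; within the scatter). The third measured compound, compound 3 `COc1ccc(S(=O)(=O)N2C[C@H](NC(=O)[C@H](CCCN)NC(=O)OC(C)(C)C)C[C@@H]2C(=O)NO)cc1`, stands far apart from both; in this assay compound 3 gives 3420 nM.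

Compound 4 `COc1ccc(S(=O)(=O)N2C[C@H](NC(=O)[C@@H](N)CCCN)C[C@@H]2C(=O)NO)cc1` is compound 2 with one change: amino in place of methyl on a saturated chain carbon, four bonds along the chain from an amine nitrogen and a carbonyl carbon. The same change has been measured once, from compound 1 to compound 3, where it produced a 26-fold higher number from compound 1 to compound 3 (1.42 log units; beyond the scatter). That step is the only one that bears directly on the move from compound 2 to compound 4, and nothing in the other measured step suggests that removing the tert-butoxycarbonyl group alters how the amine-for-methyl swap plays out. Compound 4 is therefore expected to sit well above compound 2 in this assay, with a step of about a 26-fold higher number from compound 2 to compound 4 (1.41 log units; beyond the scatter). Because compound 3 gives 3420 nM, the estimate for compound 4 is 2500 nM, expected to lie between 900 nM and 7000 nM.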

Compound 4, half-maximal inhibitory concentration: 154 nM
Estimate against measurement, compound 4: 16-fold (1.21 log units) above; measured number outside the range, below it.
By their numbers in this assay, from the lowest: compounds 2, 1 and 4 (each within the scatter of the next); then compound 3.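

In this assay, the amino-for-methyl change at this position does not have one size, since on the core with the free amine it is small, a 1.6-fold higher number from compound 2 to compound 4 (0.20 log units; within the scatter), and it differs clearly from the large step seen with tert-butoxycarbonyl in place: the same change on two cores in this assay, a 26-fold higher number (1.42 log units; beyond the scatter) from compound 1 to compound 3 and a 1.6-fold higher number (0.20 log units; within the scatter) from compound 2 to compound 4, 17-fold (1.22 log units) apart, beyond the scatter of two such steps. The loss of tert-butoxycarbonyl likewise depends on the chain, as it matters strongly once the amino group is present, a 22-fold lower number from compound 3 to compound 4 (1.35 log units; beyond the scatter), and not on the butyl chain: the same change on two cores in this assay, a 1.3-fold lower number (0.13 log units; within the scatter) from compound 1 to compound 2 and a 22-fold lower number (1.35 log units; beyond the scatter) from compound 3 to compound 4, 17-fold (1.22 log units) apart, beyond the scatter of two such steps. Among these four compounds, the two changes therefore do not add independently, and only compound 3, which carries both the 3-aminopropyl chain and tert-butoxycarbonyl, stands apart from the rest.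

The compounds leave open whether a carboxylic acid or a hydroxyl group at the end of the chain would behave as the amino group does, and whether a longer chain ending in an amine would keep the number of compound 4. They also leave open whether an acetyl group on the amine nitrogen would reproduce the large shift seen with tert-butoxycarbonyl.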